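The compounds below may be only part of what the source reports. "The series", "measured", "known", "first", "only" and "open" are said of these compounds alone.

Measured so far:
compound 1, `COc1ccccc1CN(C)C(=O)Nc1c(-c2ccccc2)c2cc(C)c(C)cc2c(=O)n1C` — 23 nM
compound 2, `CN(Cc1ccccc1Cl)C(=O)Nc1c(-c2ccc(F)cc2)c2ccccc2c(=O)n1C` — 480 nM
compound 3, `CN(Cc1cc(C(F)(F)F)cc(C(F)(F)F)c1)C(=O)c1c(-c2ccccc2)c2ccccc2c(=O)n1C` — 1.2 nM

Of the compounds shown here, three sharing one core have been tested in an assay on IM-9 cells for binding affinity to Substance-P receptor (Homo sapiens); on this read-out higher numbers stand for weaker inhibition and lower numbers for stronger inhibition. Compound 1 has the second highest of the three numbers: compound 3 sits below it by a gap beyond the scatter, and compound 2 sits above it by a gap beyond the scatter.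

Compound 4, `Cc1cc(C)cc(CN(C)C(=O)Nc2c(-c3ccccc3)c3cc(C)c(C)cc3c(=O)n2C)c1`, differs from compound 1 in a single place: 3,5-dimethylphenyl in place of 2-methoxyphenyl on a saturated chain carbon bound to an amide-type nitrogen. The rest of the molecule is unchanged.

Among the measured compounds shown here, no pair of measured compounds differs in just one place, so no directly comparable step exists. For the measured compounds named here, compound 3, whose benzyl ring carries two trifluoromethyl groups, gives 1.2 nM, and compound 1 with its single methoxy group gives 23 nM; the two differ in more than the benzyl ring, so this is only a hint. On that hint, a moderate move toward lower numbers is expected in this assay, a 3.8-fold lower number from compound 1 to compound 4 (0.58 log units; beyond the scatter). Compound 4 is therefore estimated at 6 nM, with a likely range from 1.5 nM to 25 nM.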

Compound 4, half-maximal inhibitory concentration: 28 nM
Compound 4: middle estimate off by 4.7-fold (0.67 log units), on the low side; measured number above the stated range.
By their numbers in this assay, from the lowest: compound 3; then compounds 1 and 4 (each within the scatter of the next); then compound 2.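

In this assay, replacing 2-methoxyphenyl with 3,5-dimethylphenyl gives a 1.2-fold higher number from compound 1 to compound 4 (0.09 log units; within the scatter) and so produces no change that can be told apart from the scatter. This first one-place comparison shows that, on the core of compound 1, the methoxy group can give way to two methyl groups with no detectable effect on the read-out, even though the oxygen and its hydrogen-bond acceptor leave with it. Nothing measured here explains why these two benzyl groups read alike.

Going by these compounds, two neutral aromatic rings cannot show how far this tolerance extends, so it remains open whether a benzyl ring carrying an amine or a carboxylic acid would keep the number in the same range. A longer chain between the ring and the amide-type nitrogen is equally untested by the compounds shown.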